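The source may report more compounds than this note shows. Statements on the series, on what has been measured and on what is new or still open speak of the compounds shown alone.

Compound 1 `Cc1cccc(Oc2ccnc(N3CCC[C@H]3C(=O)NCCCn3ccnc3)n2)c1` was tested in an assay on isolated protein for inhibition of RAC-alpha serine/threonine-protein kinase (Homo sapiens), read by HTRF, tested at 10 uM (a lower number here means less inhibition, a higher number more inhibition at the concentration tested (going by the name of the read-out)), where compound 1 gives 0%. A second compound, compound 2 `COC[C@@H]1CCCN1C(=O)[C@@H]1CCCN1c1nccc(Nc2ccccc2)n1`, which shares a core with compound 1 but carries a different amide partner and a different group on the core, was run in the same assay; in this assay compound 2 gives 0%. The two readings lie within the usual scatter of each other, so neither compound can be said to inhibit more than the other; both show no measurable inhibition at the concentration tested.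

Compound 3 `Cc1cccc(Oc2ccnc(N3CCC[C@H]3C(=O)NCc3cccnc3)n2)c1` has not yet been measured. It differs from compound 1 in one place: pyridin-3-yl in place of 2-(1H-imidazol-1-yl)ethyl on a saturated chain carbon bound to an amide-type nitrogen. Among the compounds with values here, no step between two measured compounds is available to show how a change at this position shifts the read-out, and the two readings known so far offer no direction. The step from compound 1 to compound 3 is therefore expected to be none beyond the scatter, a number 2 percentage points higher from compound 1 to compound 3 (within the scatter). Compound 3 is estimated to give 2%, within a range from 0% to 15%.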

Compound 3, a percentage reported as inhibition, at one concentration (the size of the read-out at that concentration, not a potency): 0%
Beside the measured number, compound 3's estimate is 2 percentage points above it; low and high end bracket the measured number.
By their numbers in this assay, from the lowest: compounds 1, 2 and 3 (each within the scatter of the next).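

In this assay, within the data shown here, putting pyridin-3-yl in place of 2-(1H-imidazol-1-yl)ethyl on a saturated chain carbon bound to an amide-type nitrogen gives no change at the digits printed from compound 1 to compound 3 (within the scatter), the first step in this set that changes only one place. It shows that exchanging one aromatic ring for another at this position, read further out as 3-(1H-imidazol-1-yl)propyl to (pyridin-3-yl)methyl, does not bring out measurable inhibition at the concentration tested, though with no inhibition on either side of the step, it cannot show whether the two groups differ in their effect. Nothing measured here offers an explanation for this result.

On these data alone, it remains open whether any group at this position can produce measurable inhibition, for example a simple phenyl ring, a carboxylic acid or an amine on a longer chain. Until one compound in this family gives a clear signal, the effect of a change at this position cannot be sized.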